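The compounds below may be only part of what the source reports. "The series", "measured", "known", "first", "only" and "open" are said of these compounds alone.

So far, two compounds sharing one core have been tested in an ADME assay on microsomes from liver (Rattus norvegicus) for metabolic stability; a lower number here means that the compound disappears faster, a higher number that the compound lasts longer. Compound 1 (`COc1cc(OCc2cccc(-c3cnc(OC)cn3)c2)c2cc(-c3cn4nc(OC)sc4n3)oc2c1`) gives 1.62 h. Compound 2 (`CNC(=O)c1ccc(-c2nc(COc3cc(OC)cc4oc(-c5cn6nc(OC)sc6n5)cc34)cs2)cc1`) gives 0.517 h, the lower of the two numbers, and its gap to compound 1 lies beyond the usual scatter of repeated measurements. These two compounds differ in more than one place, so their gap cannot be pinned on any single group.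

Compound 3 (`COc1cc(OCc2csc(-c3ccc(S(C)(=O)=O)cc3)n2)c2cc(-c3cn4nc(OC)sc4n3)oc2c1`) matches compound 2 except for one change: methylsulfonyl in place of methylcarbamoyl on an aromatic carbon, para to a large group (methylsulfonyl in place of methylcarbamoyl on an aromatic carbon). Among the compounds with values here, no measured pair shows this swap, so the expectation is only a rough one: a small rise in half-life, not beyond the scatter. The estimated step is a 1.4-fold higher number from compound 2 to compound 3 (0.13 log units; within the scatter). For compound 3 the expected half-life is 0.7 h, with an estimated range of 0.3 h to 1.6 h.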

Compound 3, half-life: 1.12 h
Estimate against measurement, compound 3: 1.6-fold (0.20 log units) below, within the range that was stated.
By their numbers in this assay, from the lowest: compound 2; then compounds 3 and 1 (each within the scatter of the next).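

In this assay, placing methylsulfonyl in place of methylcarbamoyl on this aromatic carbon, para to a large group, gives a 2.2-fold higher number from compound 2 to compound 3 (0.34 log units; beyond the scatter), the first difference here that can be tied to a single place on the molecule. Both groups have 4 heavy atoms and no ring, but hydrogen-bond donors go from 1 to 0 and hydrogen-bond acceptors from 1 to 2, and this single pair cannot separate those differences or show which one matters. Nothing available explains the higher half-life.

On these data alone, it remains open whether other groups at this position, such as a nitrile, a carboxylic acid or an amine, would lengthen or shorten the half-life further. Also open, as far as these compounds go, is whether this swap would have a similar effect on a different core.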